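The compounds below may be only part of what the source reports. "The series", "measured", "known", "first", "only" and "open" are said of these compounds alone.

Compound 2, `Cc1ccnn1-c1ccc(Cl)c(C(=O)NC(=O)Nc2nc3ccc(S(=O)(=O)C4CCN(C)CC4)cc3s2)c1`, was tested in an assay on HEK293 cells for displacement of a labelled ligand from growth hormone secretagogue receptor type 1 (Homo sapiens), with a stated time of 60 min (a lower number here means a stronger inhibitor, a higher number a weaker inhibitor), where compound 2 gives 33 nM. This is the higher of the two numbers recorded so far. The other belongs to compound 1, `CN1CCN(CCCS(=O)(=O)c2ccc3nc(NC(=O)NC(=O)c4cc(-n5cccn5)ccc4Cl)sc3c2)CC1`, which in this assay gives 0.67 nM; the gap between these two values lies beyond the usual scatter. The two compounds differ in more than one place, so that gap cannot be assigned to any single change.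

Compound 3, `CN1CCC(S(=O)(=O)c2ccc3nc(NC(=O)NC(=O)c4cc(-n5cccn5)ccc4Cl)sc3c2)CC1`, has not yet been measured. It differs from compound 2 in one place: hydrogen in place of methyl on an aromatic carbon. With the methyl gone, compound 3 carries the same 1H-pyrazol-1-yl group as compound 1, while keeping the sulfonyl substituent of compound 2. Going by the values given here, no measured pair isolates this change. Compound 1 carries this same unsubstituted pyrazole and gives 0.67 nM in this assay. On that ground the step is expected to be a 4.1-fold lower number from compound 2 to compound 3 (0.62 log units; beyond the scatter), toward a lower number. Compound 3 is therefore estimated to give 8 nM in this assay, with a range from 1.5 nM to 40 nM.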

Compound 3, half-maximal inhibitory concentration in the growth hormone secretagogue receptor type 1 assay: 15 nM
The estimate for compound 3 lay 1.9-fold (0.27 log units) below the measured number; measured number inside the range.
By their numbers in the growth hormone secretagogue receptor type 1 assay, from the lowest: compound 1; then compound 3; then compound 2.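

Going by these compounds alone, compound 3 gives the first direct reading of the methyl on the pyrazole: in the growth hormone secretagogue receptor type 1 assay compound 2 gives 33 nM and compound 3 gives 15 nM. In the growth hormone secretagogue receptor type 1 assay the change from 5-methyl-1H-pyrazol-1-yl to 1H-pyrazol-1-yl is a 2.2-fold lower number from compound 2 to compound 3 (0.34 log units; beyond the scatter) and is thus a modest step at this position. The second single change, 1-methylpiperidin-4-yl in place of 3-(4-methylpiperazin-1-yl)propyl on the sulfonyl sulfur, is a 22-fold higher number from compound 1 to compound 3 (1.35 log units; beyond the scatter) and is clearly the larger of the two steps, so in this set the sulfonyl substituent weighs more than the pyrazole methyl. In a physicochemical assay for lipophilicity (on this read-out lower numbers stand for lower lipophilicity and higher numbers for higher lipophilicity), compound 2 gives 2.6 and compound 3 gives 2.5. In the physicochemical assay the methyl change gives a number 0.10 log units lower from compound 2 to compound 3 (within the scatter) and so brings no separable shift to set beside the binding step.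

No supporting information bears on why either binding step has the size it has. The compounds shown leave open whether an ethyl group or a chlorine atom on that aromatic carbon would keep the reading near either pyrazole, and whether the methyl step would have the same size in the presence of the 3-(4-methylpiperazin-1-yl)propyl group or a shorter 2-(4-methylpiperazin-1-yl)ethyl chain on the sulfonyl sulfur.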